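This account rests on a few compounds, and the source may have more. Where it says the series, first, only, none or still open, it means among the compounds named here.

Measured compounds:
- compound 1, `O=[N+]([O-])c1cn2c(n1)[S@+]([O-])C[C@H](OCc1ccc(OC(F)(F)F)cc1)C2`, with 88%
- compound 2, `O=[N+]([O-])c1cn2c(n1)[S+]([O-])CC(OCc1ccc(-c3ccc(OC(F)(F)F)cc3)cn1)C2`, with 78%

The measurement in question is an ADME assay on microsomes from liver (Homo sapiens) for metabolic stability, with a stated time of 1 h; on this read-out higher numbers stand for a more stable compound and lower numbers for a less stable compound. Within the data shown here, only two compounds have numbers so far. In this assay compound 1 gives 88%, which is the higher of the two numbers, and in the same assay compound 2 gives 78%. The gap between them lies within the usual scatter of repeated measurements, so the two values cannot be told apart and neither compound can be called more stable than the other.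

The step of interest leads from compound 1 to compound 3, `O=[N+]([O-])c1cn2c(n1)[S@+]([O-])C[C@@H](OCc1ccc(OC(F)(F)F)cc1)C2`. The difference between the two is the two compounds have the same atoms and bonds and differ only in configuration as drawn: 1 of 2 stereo elements differ; a stereocentre at a saturated ring carbon is drawn R in compound 1 and S in compound 3. Among the measured compounds shown here, no step between two measured compounds of this kind is available for comparison, so there is no reference for how such a change tends to affect the read-out. Given that the two compounds share every atom and bond, the change is expected to produce no step beyond the scatter in this assay, and the expected step of a number 4 percentage points lower from compound 1 to compound 3 (within the scatter) reflects this. Compound 3 is therefore estimated at 84%, in a range from 70% to 95%.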

Compound 3, percent of the compound remaining: 82%
Compound 3: the middle estimate sits 2 percentage points above what was measured; low and high end bracket the measured number.
By their numbers in this assay, from the lowest: compounds 2, 3 and 1 (each within the scatter of the next).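

Turning the stereocentre at a saturated ring carbon from R to S, with the other stereo element left as drawn, goes with a number 6 percentage points lower from compound 1 to compound 3 (within the scatter) in this assay. Among these compounds, this is the first comparison here between two compounds that differ in one place, and it shows that, for this pair, the drawn configuration at this carbon does not separate the two compounds on this read-out. The comparison is unusually direct, since no atom or bond enters or leaves and nothing else can stand behind the step: the fact that compounds 1 and 3 differ only in the configuration as drawn

The compounds shown leave open whether the second stereo element, which is the same in both compounds, would matter if it were changed, and whether the same change would stay within the scatter on a compound with a different side chain, such as the biaryl side chain of compound 2. They also leave open what would happen to this assay if a quite different group, such as an amine or a carboxylic acid, took the place of the trifluoromethoxy group.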